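Dropping one methoxy group: expected effect on cell inhibition

The source may hold more compounds than are shown below. What is called first, only, known or untested is meant among the compounds shown, and "the series" means these compounds.

Compound 2 `COc1cc(C(=O)NNC(=S)Nc2csc(-c3ccc(C)cc3)c2)cc(OC)c1OC` was tested in a functional assay on U-373MG ATCC cells (Homo sapiens) for inhibition, read by colorimetric assay and MTT assay, with a stated time of 72 h (a lower number here means a stronger inhibitor, a higher number a weaker inhibitor), where compound 2 gives 47000 nM. Among the three compounds measured so far it carries the highest number, yet its neighbours lie close: compound 1 `COc1cc(C(=O)NNC(=S)Nc2csc(-c3ccccc3)c2)cc(OC)c1OC` gives 44000 nM in this assay, and compound 3 `COc1ccc(C(=O)NNC(=S)Nc2csc(-c3ccccc3)c2)cc1` gives 41000 nM. Among the compounds with values here, the one single-point step recorded, a 1.1-fold higher number from compound 1 to compound 2 (0.03 log units; within the scatter), shows that a methyl in place of hydrogen on an aromatic carbon left the number essentially unchanged.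

Compound 4 `COc1cc(OC)cc(C(=O)NNC(=S)Nc2csc(-c3ccc(C)cc3)c2)c1` differs from compound 2 by a single change: hydrogen in place of methoxy on an aromatic carbon. Within the data shown here, no measured step removes exactly this methoxy, but compound 1 and compound 3 , which differ in how many methoxy groups decorate that same ring, return numbers within the scatter of each other. Nothing here therefore points to a shift of any direction, and the expected step from compound 2 to compound 4 is a 1.0-fold lower number from compound 2 to compound 4 (0.02 log units; within the scatter). Compound 4 is accordingly estimated at 45000 nM in this assay, with a range from 25000 nM to 80000 nM.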

Compound 4, half-maximal inhibitory concentration: 41000 nM
For compound 4 the middle estimate is 1.1-fold (0.04 log units) above the measured one; the range from low to high includes it.
By their numbers in this assay, from the lowest: compounds 3, 4, 1 and 2 (each within the scatter of the next).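

Within the data shown here, the step read in this assay is a 1.1-fold lower number from compound 2 to compound 4 (0.06 log units; within the scatter) and it gives the first direct reading at this position: hydrogen can stand in place of the methoxy that is ortho to two methoxy groups and para to a large group, with the two numbers remaining within the scatter of each other. Among these compounds, until now, the only single-place step among the compounds concerned a methyl elsewhere in the molecule, so this position had not been read directly. No measured evidence bears on why the numbers stay so close.

On these data alone, whether an amine or a carboxylic acid at this position would give a number outside the scatter remains open. So does the outcome of replacing the methoxy with a longer chain such as butoxy.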